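Iodo for 4-hydroxyphenyl at the aryl position of compound 3

This account rests on a few compounds, and the source may have more. Where it says the series, first, only, none or still open, it means among the compounds named here.

Measured compounds in an ADME assay on HEL cells (Homo sapiens) for cytotoxicity, with a stated time of 3 days; on this read-out higher numbers stand for lower toxicity in this test and lower numbers for higher toxicity in this test:
compound 1 `Cc1cc(-c2ccc(O)cc2)c2ncc(CSCCc3ccccc3)n2c1` gives 20 ug/mL
compound 2 `Cc1cc(-c2ccsc2)c2ncc(CSCCc3ccccc3)n2c1` gives 100 ug/mL
compound 3 `Cc1cc(-c2ccc(O)cc2)cn2c(CSCCc3ccccc3)cnc12` gives >= 100 ug/mL

Compound 3 stands at the upper edge of the numbers seen so far. Its value in this assay is a limit of the assay and not a number, as noted in the limit of >= 100 ug/mL in this assay, at which 1 of the 3 values shown sits. Compound 4 `Cc1cc(I)cn2c(CSCCc3ccccc3)cnc12` is not yet measured; it differs from compound 3 as follows: iodo in place of 4-hydroxyphenyl on an aromatic carbon.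

Going by the values given here, one measured step bears on this change, since it also removes 4-hydroxyphenyl from an aromatic carbon: a 5.0-fold higher number from compound 1 to compound 2 (0.70 log units; beyond the scatter). That step went toward lower toxicity when the 4-hydroxyphenyl left, though the group that entered there was thiophen-3-yl, not iodo, and the core was that of compound 1 rather than that of compound 3. Compound 3 already sits at the limit, so there is little room for the number to be reported higher; the change is expected to give no step beyond the scatter in this assay, and the result is likely to be another limit. The estimated step is a number no higher from compound 3 to compound 4 (the limit leaves the size open). Compound 4 is therefore expected to give 100 ug/mL, within a range of 50 ug/mL to 200 ug/mL.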

Compound 4, minimum cytotoxic concentration: >= 0.8 ug/mL
Compound 4: no number, only a limit (the forecaster's own chance of this, stated with the estimate: 70%); the middle value is on the limit's open side.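

In this assay compound 3 and compound 4 each give only a limit of the assay and not a number, so no step can be read between them. The compounds shown leave open how iodo in place of 4-hydroxyphenyl shifts the minimum cytotoxic concentration on this core.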